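This account rests on a few compounds, and the source may have more. Where it says the series, first, only, none or still open, it means among the compounds named here.

Measured compounds:
- Compound 1 `CC(C)=CCCC1=CC[C@H](C(=O)Nc2ccc(O)cc2)[C@@H](c2ccccc2)C1` gives > 23000 nM in an assay on isolated protein for inhibition of Apoptosis regulator Bcl-2 (Homo sapiens), read by fluorescence polarization, with stated times of 5 min and 10 min (a higher number here means a weaker inhibitor, a lower number a stronger inhibitor), which is a limit of the assay rather than a number.
- Compound 2 `CC(C)=CCCC1=CC[C@@H](C(=O)N(C)C)[C@H](c2ccccc2)C1` gives > 23000 nM in this assay, again a limit and not a number.

Among the measured compounds shown here, compound 1 therefore stands at the edge of what this assay reports: only a limit is known for it, and the same holds for compound 2, so that the limit of > 23000 nM in this assay, at which 2 of the 2 values shown sit, is all the evidence there is, with no measured step between the two.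

The compound still to be tested is compound 3 `CON(C)C(=O)[C@H]1CC=C(CCC=C(C)C)C[C@@H]1c1ccccc1`. It differs from compound 1 in one place: methoxy(methyl)amino in place of (4-hydroxyphenyl)amino on a carbonyl carbon. The step from compound 1 to compound 3 thus exchanges a larger amide substituent for a small one on the carbonyl carbon.

For the measured compounds named here, no measured step is available to size this change. Since compound 2, which also carries a small amide substituent on the same carbonyl carbon, gives > 23000 nM, a limit, no movement beyond the scatter is expected from compound 1 to compound 3 in this assay, and compound 3 is expected most likely to sit at the limit as well. The estimated value for compound 3 is 40000 nM, with a range from 15000 nM to 200000 nM, which corresponds to an expected step that the limit leaves unreadable from compound 1 to compound 3.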

Compound 3, inhibition constant: 300 nM
Compound 3: the middle estimate sits 130-fold (2.12 log units) above what was measured; measured number outside the range, below it.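

In this assay, the carbonyl carbon proves to be a place where the amide substituent can decide whether the compound registers at all: methoxy(methyl)amino in place of (4-hydroxyphenyl)amino gives an at least 76-fold lower number from compound 1 to compound 3 (1.88 log units; beyond the scatter). Among the compounds shown here, this is the first step that can be read, and it shows that the shared core can reach a measured number in this assay once this one substituent is exchanged. The other two compounds stay at a limit of the assay and not at a number: the limit of > 23000 nM in this assay, at which 2 of the 3 values shown sit.

From the compounds shown here alone, the full size of the step stays open, since compound 1 supplies only a limit. Also open, going by these compounds, is whether ethoxy(methyl)amino, a methyl ester or a carboxylic acid on the same carbonyl carbon would hold, raise or lose this result.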